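This account rests on a few compounds, and the source may have more. Where it says the series, first, only, none or still open, it means among the compounds named here.

Three compounds share one core and differ only in the ring attached to the carbonyl carbon of the amide. Compound 1 `CCN1CCN(c2cc(C)c3cc(NC(=O)c4ccccc4F)ccc3n2)CC1` carries a 2-fluorophenyl group there; in a functional assay on MCF7 cells (Homo sapiens) for antiproliferative activity, read by MTT assay, with a stated time of 72 h (a lower number here means a stronger inhibitor, a higher number a weaker inhibitor), compound 1 gives 32600 nM. Compound 2 `CCN1CCN(c2cc(C)c3cc(NC(=O)c4cccc(Cl)c4)ccc3n2)CC1` carries a 3-chlorophenyl group, and in this assay compound 2 gives 3820 nM. Compound 3 `CCc1ccc(C(=O)Nc2ccc3nc(N4CCN(CC)CC4)cc(C)c3c2)cc1` carries a 4-ethylphenyl group, and in this assay compound 3 gives 3060 nM. Going by the values given here, compound 3 thus has the lowest number of the three, but the step of a 1.2-fold lower number from compound 2 to compound 3 (0.10 log units; within the scatter) is within the scatter, so compound 2 and compound 3 cannot be ranked against each other; only the step of an 11-fold lower number from compound 1 to compound 3 (1.03 log units; beyond the scatter) and the step of an 8.5-fold lower number from compound 1 to compound 2 (0.93 log units; beyond the scatter) are clear.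

Compound 4 `CCc1ccccc1C(=O)Nc1ccc2nc(N3CCN(CC)CC3)cc(C)c2c1` is compound 3 with its atoms joined differently: 2-ethylphenyl in place of 4-ethylphenyl on a carbonyl carbon. Among the compounds with values here, the only measured compound with a group at the 2-position of that ring is compound 1, and it has the weakest result, though its group is fluorine rather than ethyl. Taking that as a guide, compound 4 is expected to show a step of a 3.9-fold higher number from compound 3 to compound 4 (0.59 log units; beyond the scatter) toward a higher number, and the estimate for compound 4 in this assay is 12000 nM, with a range from 4000 nM to 40000 nM.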

Compound 4, half-maximal inhibitory concentration: 15800 nM
Beside the measured number, compound 4's estimate is 1.3-fold (0.12 log units) below it; the range from low to high includes it.
By their numbers in this assay, from the lowest: compounds 3 and 2 (each within the scatter of the next); then compound 4; then compound 1.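

In this assay, the ethyl group's place on the ring matters on its own: with the same atoms, joined differently, the change from 4-ethylphenyl to 2-ethylphenyl gives a 5.2-fold higher number from compound 3 to compound 4 (0.71 log units; beyond the scatter) and brings a clear gap where the earlier ring changes left only fluorine to suggest one. The 2-ethylphenyl compound also stands apart from the 3-chlorophenyl compound, with a 4.1-fold higher number from compound 2 to compound 4 (0.62 log units; beyond the scatter) as the step, so the two compounds with a 2-substituted ring, compound 1 and compound 4, now both have higher numbers than compound 2 and compound 3, and no compound shown goes against this. The group at that place still counts, as ethyl in place of fluoro gives a 2.1-fold lower number from compound 1 to compound 4 (0.31 log units; beyond the scatter) (a smaller step, only just beyond the scatter), but nothing measured here explains either change.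

A 4-fluorophenyl group would separate the effect of fluorine from that of its place, since compound 1 is the only fluorine compound shown. From the compounds shown here alone, it also remains open how a 3-ethylphenyl group, or a 4-aminophenyl or 4-carboxyphenyl group, would compare with compound 3.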